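Ring swap on the thiocarbonyl carbon: outlook for compound 4

The compounds below may be only part of what the source reports. "The series", "measured", "known", "first", "only" and "open" are said of these compounds alone.

compound 1 `N/C(=N\NC(=S)N1CCOCC1)c1ccccn1`: 29.2%
compound 2 `Cc1ccnc(/C(N)=N/NC(=S)N2CCOCC2)c1`: 33.6%
compound 3 `Cc1ccnc(/C(N)=N/NC(=S)N2CCCCCC2)c1`: 36.3%

In a functional assay on A-431 cells (Homo sapiens) for cytotoxicity, read by MTT assay, with a stated time of 72 h, tested at 1 uM (on this read-out lower numbers stand for less inhibition of growth and higher numbers for more inhibition of growth at the one concentration tested), compound 2 stands second highest of the three numbers; compound 3 is nearest and compound 1 furthest, and both gaps are within the scatter. Among the compounds with values here, the only measured step, a number 4.4 percentage points higher from compound 1 to compound 2 (within the scatter), concerns a methyl in place of hydrogen on an aromatic carbon and does not touch the part changed here. Compound 4 `Cc1ccnc(/C(N)=N/NC(=S)N2CCCCC2)c1` differs from compound 2 by piperidin-1-yl in place of morpholin-4-yl on a thiocarbonyl carbon. Compound 3 carries a different ring on that same thiocarbonyl carbon, and its value and that of compound 2 lie within the scatter of each other. Compound 4 is therefore expected to show a step of a number 1.4 percentage points higher from compound 2 to compound 4 (within the scatter), nothing beyond the scatter, with an estimate of 35% and a range from 24% to 46%.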

Compound 4, percent growth inhibition at one concentration: 31.1%
The estimate for compound 4 lay 3.9 percentage points above the measured number, within the range that was stated.
By their numbers in this assay, from the lowest: compounds 1, 4, 2 and 3 (each within the scatter of the next).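

Within the data shown here, compound 2 and compound 4 give the first direct reading at this position: in this assay, piperidin-1-yl in place of morpholin-4-yl on a thiocarbonyl carbon gives a number 2.5 percentage points lower from compound 2 to compound 4 (within the scatter). The ring oxygen of morpholin-4-yl can therefore be exchanged for carbon here without a step beyond the scatter. Nothing at hand explains this result.

Going by these compounds, whether a diethylamino group or 4-methylpiperazin-1-yl on the thiocarbonyl carbon would give a step beyond the scatter remains open. On these data alone, with a single concentration in this assay, any difference in potency between compound 2 and compound 4 at other concentrations also remains open.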